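The compounds below may be only part of what the source reports. "The series", "measured", "known", "first", "only" and "open" are said of these compounds alone.

Measured in an ADME assay on HepG2 cells (Homo sapiens) for cytotoxicity, read by MTT assay, with a stated time of 72 h; on this read-out lower numbers stand for higher toxicity in this test and higher numbers for lower toxicity in this test:

- Compound 1 `O=[N+]([O-])c1c(CS(=O)(=O)c2ccccc2)nc2c(-c3ccc(C(F)(F)F)cc3)cc(Cl)cn12`: > 3900 nM, a limit and not a number
- Compound 2 `O=[N+]([O-])c1c(CS(=O)(=O)c2ccccc2)nc2c(-c3ccccc3C(F)(F)F)cc(Cl)cn12`: 22700 nM

Among the measured compounds shown here, compound 2, at 22700 nM, holds the only actual number in this assay, so it can be ranked against nothing. The other result is a limit.

The next compound is compound 3 `O=[N+]([O-])c1c(CS(=O)(=O)c2ccccc2)nc2c(-c3cccnc3)cc(Cl)cn12`. The change from compound 2 is pyridin-3-yl in place of 2-(trifluoromethyl)phenyl on an aromatic carbon, with the rest of the core untouched.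

For the measured compounds named here, only one measured step bears on this position, a step that the limit leaves unreadable from compound 1 to compound 2. Going by the values given here, it exchanged one trifluoromethyl-bearing phenyl group for another, and no measured step introduces a pyridin-3-yl group. For compound 1 the size of that step cannot be read because of the limit of > 3900 nM in this assay, at which 1 of the 2 values shown sits. The data therefore offer neither a size nor a direction for the new change, and no shift beyond the usual scatter is expected.

The estimated change is a 1.1-fold higher number from compound 2 to compound 3 (0.04 log units; within the scatter). For compound 3 the expected value is 25000 nM, with an estimated range from 8000 nM to 80000 nM.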

Compound 3, half-maximal cytotoxic concentration: > 31300 nM
Compound 3: no number, only a limit; the forecaster's own chance of this, stated with the estimate: 40%; at least 1.2-fold (0.09 log units) between middle value and limit.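

Among the compounds shown here, at this position, pyridin-3-yl in place of 2-(trifluoromethyl)phenyl gives the first step with a readable direction in this assay: an at least 1.3-fold higher number from compound 2 to compound 3 (0.13 log units; that floor lies within the scatter). Its floor does not establish a shift beyond the usual scatter, but the exchange of a carbon-only ring bearing trifluoromethyl for a ring with one nitrogen produced no fall in the number, so the trifluoromethyl group is not required to keep the read-out at this level in the compounds shown. The steps from compound 1 to compound 2 and from compound 1 to compound 3 still cannot be read: the limit of > 3900 nM in this assay, at which 1 of the 3 values shown sits.

The true size of the step to compound 3 stays open, and the swap changes the ring nitrogen and the trifluoromethyl group together, so the compounds shown do not say which of the two matters. A plain phenyl group at this place would separate the two, and a pyridin-3-yl ring carrying an amine or a carboxylic acid would show how much further this position can be changed.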